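Urea aryl swap in a zebrafish microscopy assay

The compounds below may be only part of what the source reports. "The series", "measured", "known", "first", "only" and "open" are said of these compounds alone.

Measured so far:
Compound 1, `CCN1CCc2c(sc(NC(=O)Nc3ccc(I)cc3)c2C(N)=O)C1`: 1620 nM
Compound 2, `CC(C)(C)OC(=O)CCCCN1CCc2c(sc(NC(=O)Nc3ccc(Cl)cc3)c2C(N)=O)C1`: 710 nM
Compound 3, `CCN1CCc2c(sc(NC(=O)c3ccccc3)c2C(N)=O)C1`: a limit, > 25000 nM

In a functional assay (strain AB) with Danio rerio as the target, read by microscopy, with a stated time of 1 h (a lower number here means that less compound is needed, a higher number that more compound is needed for the effect), compound 1 gives 1620 nM, the higher of the two numbers shown; compound 2 gives 710 nM. For compound 3 only a limit is reported, > 25000 nM, and the limit of > 25000 nM in this assay, at which 1 of the 3 values shown sits, marks where it sits. Going by the values given here, the one measured step is an at least 15-fold higher number from compound 1 to compound 3 (1.18 log units; beyond the scatter), which concerns the loss of the whole aryl-amino part and not the change now at hand. Compound 4, `CCN1CCc2c(sc(NC(=O)Nc3cccc(Cl)c3Cl)c2C(N)=O)C1`, differs from compound 1 only as 2,3-dichlorophenyl in place of 4-iodophenyl on an amide-type nitrogen. Among the compounds with values here, no measured step speaks directly to this swap, so compound 4 is expected to stay close, with a 1.2-fold lower number from compound 1 to compound 4 (0.10 log units; within the scatter). The estimate for compound 4 is 1300 nM, within 400 nM to 4500 nM.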

Compound 4, half-maximal effective concentration: 17400 nM
For compound 4 the middle estimate is 13-fold (1.13 log units) below the measured one; the whole stated range lies below it.
By their numbers in this assay, from the lowest: compound 2; then compound 1; then compound 4. At a limit, above all of these: compound 3.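

In this assay, keeping the aryl-amino part is not enough: 2,3-dichlorophenyl in place of 4-iodophenyl on an amide-type nitrogen gives an 11-fold higher number from compound 1 to compound 4 (1.03 log units; beyond the scatter). The earlier step covered only the loss of that whole part, whereas this one shows that the aryl group's substituents alone can shift the number by a large step. Nothing shown here explains the size of this step. From the compounds shown here alone, it remains open whether the loss of iodine or the arrival of the two chlorines drives it, and how a methoxy group or a nitrile on this phenyl ring would compare.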